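The source may hold more compounds than are shown below. What is called first, only, known or untested is meant among the compounds shown, and "the series" means these compounds.

The measurements come from an assay on HEK293 cells for inhibition of transient receptor potential cation channel subfamily M member 8 (Homo sapiens), read by FLIPR, with stated times of 5 min and 3 min; on this read-out lower numbers stand for stronger inhibition and higher numbers for weaker inhibition. Compound 1 `CCOC(=O)c1ccc(-c2cccc(F)c2)cc1O` reaches only the limit of this assay, > 100000 nM. Compound 2 `CCOC(=O)c1sc(-c2ccccc2)nc1OC` likewise reaches only the limit, > 100000 nM. Among the compounds with values here, compound 3 `CCn1nnc(-c2sc(-c3ccccc3OC)nc2O)n1` is the one compound here with a numerical value, giving 2790 nM in this assay. Within the data shown here, compound 2 thus stands at the limit, where two of the three values shown sit (the limit of > 100000 nM in this assay, at which 2 of the 3 values shown sit), and no pair of measured compounds differs in a single place, so no measured step is available to lean on.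

Compound 4 `CCOC(=O)c1sc(-c2ccccc2)nc1NC(=O)C(F)(F)F` is not yet measured. It differs from compound 2 in one place: ((trifluoromethyl)carbonyl)amino in place of methoxy on an aromatic carbon. Nothing measured here shows how such a change moves the value. The step of an at least 1.2-fold lower number from compound 2 to compound 4 (0.09 log units; that floor lies within the scatter) is expected to be small, a modest gain at most or none beyond the scatter. Compound 4 is therefore estimated at 80000 nM, within a range from 15000 nM to 300000 nM, with a fair chance that this assay again reports only a limit.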

Compound 4, half-maximal inhibitory concentration: 7700 nM
Estimate against measurement, compound 4: 10-fold (1.02 log units) above; measured number below the stated range.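

This position, on the aromatic carbon next to the ring nitrogen and next to the ring atom that bears an ethoxycarbonyl group, clearly matters: in this assay, putting ((trifluoromethyl)carbonyl)amino in place of methoxy gives an at least 12-fold lower number from compound 2 to compound 4 (1.11 log units; beyond the scatter). With the ethoxycarbonyl and phenyl groups kept, this single change is enough to take the shared core from a limit to a measured number. Compound 2 gives only a limit, so the true size of the step is unknown and may be larger: the limit of > 100000 nM in this assay, at which 2 of the 4 values shown sit.

Within the data shown here, whether the gain rests on the amide hydrogen, the carbonyl or the trifluoromethyl stays open, as no compound here carries a plain amine or an acetylamino group at this position. Also open, as far as these compounds go, is how a longer chain on the amide carbonyl, or a carboxylic acid in place of the ethoxycarbonyl group, would move the value.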